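The source may report more compounds than this note shows. Statements on the series, on what has been measured and on what is new or still open speak of the compounds shown alone.

Three compounds of a shared core, each carrying a furanyl or naphthyl group on one side and an aryl group on a saturated ring carbon, have been tested in a functional assay on HEp-2 cells (Homo sapiens) for cytotoxicity, read by sulforhodamine B assay, with a stated time of 48 h; on this read-out higher numbers stand for weaker inhibition and lower numbers for stronger inhibition. Compound 1 `CC(=O)N1N=C(c2ccco2)CC1c1cccc(O)c1` gives 10000 nM in this assay. Compound 2 `COc1cc(C2CC(c3ccco3)=NN2C(C)=O)cc(OC)c1OC` gives 21300 nM. Compound 3 `O=CCN1N=C(c2ccc3ccccc3c2)CC1c1ccccc1` gives 8400 nM, the lowest of the three numbers; its gap to compound 1 lies within the scatter, so the two cannot be ordered, while its gap to compound 2 lies beyond the scatter.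

Compound 4 `O=CCN1N=C(c2ccc3ccccc3c2)CC1c1cccc(Cl)c1Cl` has not yet been measured. It differs from compound 3 in one place: 2,3-dichlorophenyl in place of phenyl on a saturated ring carbon. Within the data shown here, no pair of measured compounds shares exactly this change, so there is no measured step to lean on. Among the three measured compounds the aryl group on the saturated ring carbon varies together with the other substituents, and the numbers stay close to one another, so no clear effect of that aryl group can be read from them.

On that basis compound 4 is expected to stay near compound 3, with any step a 1.3-fold lower number from compound 3 to compound 4 (0.11 log units; within the scatter) not beyond the scatter. The estimate for compound 4 in this assay is 6500 nM, with a likely range from 2500 nM to 20000 nM.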

Compound 4, half-maximal inhibitory concentration: 12500 nM
Estimate against measurement, compound 4: 1.9-fold (0.28 log units) below, within the range that was stated.
By their numbers in this assay, from the lowest: compounds 3, 1, 4 and 2 (each within the scatter of the next, the first and the last beyond it).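

Among these compounds, the pair of compound 3 and compound 4 gives the first direct reading at the saturated ring carbon next to the ring nitrogen, where the earlier compounds varied the aryl group only together with other groups. In this assay, 2,3-dichlorophenyl in place of phenyl gives a 1.5-fold higher number from compound 3 to compound 4 (0.17 log units; within the scatter) and this step lies within the scatter, so the pair shows no measurable shift in either direction from this change at this position. No measurement on hand bears on why the number holds here.

What the compounds shown leave open is whether a different group on this aryl ring, such as an amine or a carboxylic acid, would move the number beyond the scatter, and whether 2,3-dichlorophenyl would behave the same way with a furanyl group in place of the naphthyl group. They also leave open what the formylmethyl group contributes on its own, since a longer chain in its place would be needed to read that position separately from the rest of the shared core.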